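Dithiocarbamate benzamide series: varying the group on thiocarbonyl carbon

This account rests on a few compounds, and the source may have more. Where it says the series, first, only, none or still open, it means among the compounds named here.

Two compounds in the series share a core in which a benzamide bearing an aminophenyl amide is linked through a methylene and a sulfur to a thiocarbonyl carbon. Compound 1 `CN(C(=S)SCc1ccc(C(=O)Nc2ccccc2N)cc1)c1cccnc1` carries a methyl(pyridin-3-yl)amino group on that carbon; in a functional assay on HeLa cells (Homo sapiens) for antiproliferative activity, read by CCK-8 assay, with a stated time of 72 h, tested at 8 uM (a lower number here means a weaker effect, a higher number a stronger effect of the compound at the concentration tested), compound 1 gives 70.5%. Compound 2 `COc1ccc(N2CCN(C(=S)SCc3ccc(C(=O)Nc4ccccc4N)cc3)CC2)cc1` carries a piperazine group bearing a methoxyphenyl in the same place, and in this assay compound 2 gives 52.3%. Of these two numbers, compound 1 stands highest, with compound 2 lying beyond the scatter below it.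

Compound 3 `Nc1ccccc1NC(=O)c1ccc(CSC(=S)N2CCc3cc(Cl)ccc32)cc1` is the unmeasured member; it differs from compound 1 as follows: 5-chloro-2,3-dihydro-1H-indol-1-yl in place of methyl(pyridin-3-yl)amino on a thiocarbonyl carbon. Among the compounds with values here, no measured pair shows this exact exchange. Since the group on the thiocarbonyl carbon changes the read-out appreciably between compound 1 and compound 2, a modest downward step from compound 1 is expected for compound 3, of about a number 10.5 percentage points lower from compound 1 to compound 3 (beyond the scatter), near the edge of the scatter rather than far beyond it. Compound 3 is therefore estimated at 60%, with a plausible range from 40% to 78%.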

Compound 3, a percentage reported as inhibition, at one concentration (the size of the read-out at that concentration, not a potency): 65.1%
Compound 3: the middle estimate sits 5.1 percentage points below what was measured; the measured number falls inside the stated range.
By their numbers in this assay, from the lowest: compound 2; then compounds 3 and 1 (each within the scatter of the next).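

In this assay, 5-chloro-2,3-dihydro-1H-indol-1-yl in place of methyl(pyridin-3-yl)amino on a thiocarbonyl carbon gives a number 5.4 percentage points lower from compound 1 to compound 3 (within the scatter), so this read-out does not separate the two groups. Within the data shown here, the earlier compounds showed only that the group at this place can matter; this step adds that a group with one six-membered aromatic ring with 1 hetero atom and 1 hydrogen-bond acceptor can be exchanged for a group with a six-membered aromatic ring of carbon only, a five-membered non-aromatic ring, chlorine and 0 hydrogen-bond acceptors, with the step staying within the scatter.

The compounds shown do not tell whether the chlorine contributes anything at this place, a question that the plain 2,3-dihydro-1H-indol-1-yl group or its 5-fluoro counterpart would address. Also open is whether an aromatic ring is needed here at all, which a small open-chain group such as dimethylamino would test, and the single concentration gives no potency for any of these compounds. No measurement at hand bears on why the two groups read alike.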